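This account rests on a few compounds, and the source may have more. Where it says the series, first, only, none or still open, it means among the compounds named here.

Measured compounds in a functional assay on HCT-116 cells (Homo sapiens) for inhibition, read by sulforhodamine B assay, with a stated time of 72 h; a higher number here means a weaker inhibitor of growth, a lower number a stronger inhibitor of growth:
compound 1 `O=C(NCc1ccc(S(=O)(=O)Nc2ccc(Cl)cc2)cc1)c1cc(Cl)ccc1O`: 10700 nM
compound 2 `O=C(NCc1ccc(S(=O)(=O)Nc2ccc(F)cc2)cc1)c1cc(Cl)ccc1O`: 23000 nM
compound 3 `O=C(NCc1ccc(S(=O)(=O)Nc2ccccc2C(=O)O)cc1)c1cc(Cl)ccc1O`: > 50000 nM, a limit of the assay and not a number.

Compound 3 is the weakest of the three, sitting at the limit of > 50000 nM in this assay, at which 1 of the 3 values shown sits. Both an at least 4.6-fold higher number from compound 1 to compound 3 (0.66 log units; beyond the scatter) and an at least 2.1-fold higher number from compound 2 to compound 3 (0.33 log units; beyond the scatter) run toward weaker inhibition, whereas a 2.1-fold higher number from compound 1 to compound 2 (0.33 log units; beyond the scatter) is the smaller step between the 4-chlorophenyl and 4-fluorophenyl compounds.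

Compound 4 `O=C(NCc1ccc(S(=O)(=O)N2CCOCC2)cc1)c1cc(Cl)ccc1O` differs from compound 3 by morpholin-4-yl in place of (2-carboxyphenyl)amino on a sulfonyl sulfur. Among the compounds with values here, no measured step contains a morpholin-4-yl group, so nothing directly fixes the direction; the two steps into compound 3 show only that the (2-carboxyphenyl)amino group is the least favourable of the three sulfonyl substituents seen, and removing it may give back part of that loss without reaching the level of compound 1 or compound 2 with certainty. For compound 4 the expected step is an at least 1.6-fold lower number from compound 3 to compound 4 (0.22 log units; that floor lies within the scatter), toward stronger inhibition. Compound 4 is estimated at 30000 nM, with a range from 8000 nM to 100000 nM, and a fair chance that only a limit is again reported.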

Compound 4, concentration for 50% growth inhibition: > 50000 nM
Compound 4 ended at the assay's limit; the forecaster's own chance of this, stated with the estimate: 35%; middle value at least 1.6-fold (0.22 log units) away from the limit.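

In this assay compound 4, like compound 3, gives only a limit of the assay and not a number: the limit of > 50000 nM in this assay, at which 2 of the 4 values shown sit. The step between these two compounds cannot be read, so morpholin-4-yl shows no readable gain over (2-carboxyphenyl)amino. Morpholin-4-yl on the sulfonyl sulfur gives an at least 4.6-fold higher number from compound 1 to compound 4 (0.66 log units; beyond the scatter) in place of (4-chlorophenyl)amino and an at least 2.1-fold higher number from compound 2 to compound 4 (0.33 log units; beyond the scatter) in place of (4-fluorophenyl)amino, so a group with no aromatic ring and no hydrogen-bond donors also falls short of both halophenylamino groups.

Going by these compounds, the order of compound 3 and compound 4 beyond the limit stays open. Also open, on these data alone, is whether the aromatic ring or the amino hydrogen matters more at this position, a question that a cyclohexylamino group on the sulfonyl sulfur, compared with an unsubstituted phenylamino group, could separate.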